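A group exchanged on compound 2

A few compounds are considered here, and "the series" means these few. Any claim that something is new, unique, unknown or untested is made for them only; others in the source may bear on it.

compound 1 `N#Cc1ccccc1C1OCC(C/C=C\CCC(=O)O)C(c2cccnc2)O1`: 245 nM
compound 2 `CSc1ccc(OC(C)(C)C2OCC(C/C=C\CCC(=O)O)C(c3cccnc3)O2)c([N+](=O)[O-])c1`: 4.47 nM

Both compounds were tested in a functional assay for inhibition, with Homo sapiens as the target; on this read-out lower numbers stand for tighter binding and higher numbers for weaker binding. Of the two, compound 2 has the lower number, and its gap to compound 1 lies beyond the scatter, so compound 2 is the tighter binder on this read-out.

Compound 3 `CC(C)(C)c1ccc(OC(C)(C)C2OCC(C/C=C\CCC(=O)O)C(c3cccnc3)O2)cc1` has not yet been measured. It keeps the rest of compound 2 and differs in one group, on an oxygen on a saturated carbon: a group of 10 heavy atoms (10 carbon; one six-membered aromatic ring of carbon only) in place of a group of 11 heavy atoms (7 carbon, 1 nitrogen, 2 oxygen, 1 sulfur; one six-membered aromatic ring of carbon only), on an oxygen on a saturated carbon. The 4-(tert-butyl)phenyl group that enters keeps the six-membered aromatic ring of carbon only, but it is made of carbon alone.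

Among the measured compounds shown here, no measured pair differs at this place, so the size of the change can only be judged loosely. The starting point is compound 2 at 4.47 nM. A moderate move toward weaker binding is expected in this assay, probably just beyond the scatter, with a wide margin of doubt. The expected step is a 3.4-fold higher number from compound 2 to compound 3 (0.53 log units; beyond the scatter). For compound 3 the estimated value is 15 nM, with an expected range of 3 nM to 70 nM.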

Compound 3, dissociation constant: 1910 nM
Compound 3: the middle estimate sits 130-fold (2.10 log units) below what was measured; the whole stated range lies below it.
By their numbers in this assay, from the lowest: compound 2; then compound 1; then compound 3.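

In this assay, replacing the group on this oxygen with 4-(tert-butyl)phenyl gives a 430-fold higher number from compound 2 to compound 3 (2.63 log units; beyond the scatter), which shows that binding on this read-out depends strongly on what this position carries. The six-membered aromatic ring of carbon only is present on both sides of the step, so that ring alone is not enough to retain the low number of compound 2 at 4.47 nM; the large shift comes with an exchange of what the ring carries, from a group with nitrogen, oxygen and sulfur atoms and hydrogen-bond acceptors to one made of carbon alone. Nothing among the data shown explains why the step is so large.

This single step cannot separate the departure of the nitro and methylthio groups from the arrival of the tert-butyl group, so the part played by each remains unresolved. As far as these compounds go, it also remains open whether an unsubstituted phenyl group, or a phenyl group carrying a single chlorine atom or an amine, would give a number closer to that of compound 2 or that of compound 3.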